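Urea series: aryl swap on the pyrazole-ring nitrogen

A few compounds are considered here, and "the series" means these few. Any claim that something is new, unique, unknown or untested is made for them only; others in the source may bear on it.

Measured so far:
compound 1 — `CC(=O)n1ncc2c(NC(=O)NCc3cc(C(F)(F)F)nn3-c3cccc(Cl)c3)cccc21` — 17.4 nM in an assay on CHO-K1 cells for antagonist activity at transient receptor potential cation channel subfamily V member 1 (Homo sapiens), read by FLIPR and calcium flux, with a stated time of 6 min; a higher number here means a weaker inhibitor, a lower number a stronger inhibitor
compound 2 — `CC(C)(C)c1cc(CNC(=O)Nc2cccc3[nH]ncc23)n(-c2cccc(F)c2)n1` — 1.3 nM in this assay

Compound 2 holds the lower of the two numbers in this assay; compound 1 sits well above it, and the two values show a gap beyond the usual scatter. Among the compounds with values here, the two measured compounds differ in several places at once, so no single-change step is available, and no measured step connects them to the next compound.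

Compound 3, `CC(C)(C)c1ccc(-n2nc(C(C)(C)C)cc2CNC(=O)Nc2cccc3[nH]ncc23)cc1`, differs from compound 2 in one place: 4-(tert-butyl)phenyl in place of 3-fluorophenyl on an aromatic nitrogen. The series gives no direct guide to this change. Compound 3 is expected to stay close to compound 2, with a 2.3-fold higher number from compound 2 to compound 3 (0.36 log units; beyond the scatter) estimated as a small loss that may well fall within the scatter. The estimate for compound 3 in this assay is 3 nM, with a range from 0.6 nM to 15 nM.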

Compound 3, inhibition constant: 40 nM
Beside the measured number, compound 3's estimate is 13-fold (1.12 log units) below it; measured number above the stated range.
By their numbers in this assay, from the lowest: compound 2; then compound 1; then compound 3.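

In this assay, the aromatic nitrogen of the five-membered ring proves sensitive to the aryl group it carries: 4-(tert-butyl)phenyl in place of 3-fluorophenyl gives a 31-fold higher number from compound 2 to compound 3 (1.49 log units; beyond the scatter), with the rest of the molecule unchanged. Within the data shown here, this is the first single-change comparison, as compound 1 and compound 2 differ in several places at once, and it shows that these two aryl groups are not interchangeable at this nitrogen. No supporting measurement is available to explain the loss.

The two aryl groups differ in both the substituent and where it sits on the phenyl ring, and the compounds shown cannot separate those two changes. Also open, on these data alone, is how a plain phenyl, or a phenyl carrying a methoxy group or an amine, would read at this nitrogen.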